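A few compounds are considered here, and "the series" means these few. Any claim that something is new, unique, unknown or untested is made for them only; others in the source may bear on it.

Three compounds share one core, an amide bearing a trifluoromethyl group joined to a sulfonyl-linked pair of rings. Compound 1 `CC(O)(C(=O)Nc1ccc(S(=O)(=O)c2cccc(O)c2)cc1)C(F)(F)F` gives 18000 nM in a functional assay (Cavia porcellus) with sulfonylurea receptors; K-ATP channels (Homo sapiens) as the target; a higher number here means a weaker inhibitor, a lower number a stronger inhibitor. Compound 2 `Cc1cccc(S(=O)(=O)c2ccc(NC(=O)C(C)(O)C(F)(F)F)cc2)c1` gives 2200 nM in this assay, and an 8.2-fold lower number from compound 1 to compound 2 (0.91 log units; beyond the scatter). As far as these compounds go, compound 3 `Cc1ccc(S(=O)(=O)c2ccc(NC(=O)C(C)(O)C(F)(F)F)cc2)cc1` reaches only a limit of the assay, > 30000 nM, so its true value is unknown. The step of an at least 13-fold higher number from compound 2 to compound 3 (1.13 log units; beyond the scatter) is large, while an at least 1.6-fold higher number from compound 1 to compound 3 (0.22 log units; that floor lies within the scatter) stays inside the scatter. Compound 4 `CC(O)(C(=O)Nc1ccc(S(=O)(=O)c2ccc(Br)cc2)cc1)C(F)(F)F` differs from compound 3 by bromo in place of methyl on an aromatic carbon. Among the measured compounds shown here, no measured step exchanges methyl for bromo, so no step beyond the scatter is expected; the estimate is an at least 1.2-fold lower number from compound 3 to compound 4 (0.07 log units; that floor lies within the scatter). Compound 4 is therefore expected near 25000 nM, within 7000 nM to 80000 nM.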

Compound 4, half-maximal inhibitory concentration: > 30000 nM
Compound 4 ended at the assay's limit (the forecaster's own chance of this, stated with the estimate: 45%); at least 1.2-fold (0.07 log units) between middle value and limit.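

In this assay compound 4 also stops at a limit, > 30000 nM, so the step between compound 3 and compound 4 cannot be read. Methyl and bromo in this place therefore both end at the same ceiling: the limit of > 30000 nM in this assay, at which 2 of the 4 values shown sit. The 4-bromophenyl group gives an at least 13-fold higher number from compound 2 to compound 4 (1.13 log units; beyond the scatter), which matches what 4-methylphenyl showed, while the comparison with the hydroxy compound gives only an at least 1.6-fold higher number from compound 1 to compound 4 (0.22 log units; that floor lies within the scatter).

As far as these compounds go, how far compound 3 and compound 4 lie past the limit stays unknown, as does any difference between them. From the compounds shown here alone, whether an amine or a carboxylic acid in this place would give a readable value also remains open.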